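Isopropyl to benzyl on the amine chain, two cores

This account rests on a few compounds, and the source may have more. Where it says the series, first, only, none or still open, it means among the compounds named here.

Three compounds have numbers in an assay on nucleic acid for inhibition of Nucleic Acid, read by fluorescence, tested at 100 uM (on this read-out higher numbers stand for more inhibition at the one concentration tested (going by the name of the read-out) and lower numbers for less inhibition), so far. Compound 1 `CN(CCCc1ccccc1)Cc1cn(C2CCCCC2OC(=O)COc2ccccc2)nn1` gives 42% in this assay. Compound 2 `CC(C)CCN(C)Cc1cn(C2CCCCC2OC(=O)COc2ccccc2)nn1` gives 59% in this assay, the highest of the three numbers. Compound 3 `CCCCC(O)Cn1cc(CN(C)CCC(C)C)nn1` gives 47% in this assay; against compound 1 this lies within the scatter, against compound 2 it lies beyond it.

Compound 2 and compound 1 share a core and differ in one place: benzyl in place of isopropyl on a saturated chain carbon, two bonds along the chain from an amine nitrogen. On this core the change gives a number 17 percentage points lower from compound 2 to compound 1 (beyond the scatter), a modest step downward and beyond the scatter.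

Compound 3 carries a different core from compound 2; the difference between the two cores is not broken down here.

Compound 4 `CCCCC(O)Cn1cc(CN(C)CCCc2ccccc2)nn1` is not yet measured. It differs from compound 3 by benzyl in place of isopropyl on a saturated chain carbon, two bonds along the chain from an amine nitrogen, the same change as that from compound 2 to compound 1, set at a place described in the same words, so it is taken as the same change on the second core.

Among the compounds with values here, for compound 4 the expected step from compound 3 is a number 17 percentage points lower from compound 3 to compound 4 (beyond the scatter), an estimate that rests on the one earlier instance of this change, a number 17 percentage points lower from compound 2 to compound 1 (beyond the scatter), with the second core untested for it. In this assay compound 4 is therefore estimated at 30%, expected between 15% and 45%.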

Compound 4, a percentage reported as inhibition, at one concentration (the size of the read-out at that concentration, not a potency): 37%
For compound 4 the middle estimate is 7 percentage points below the measured one; the measured number falls inside the stated range.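

On the second core, benzyl in place of isopropyl on a saturated chain carbon, two bonds along the chain from an amine nitrogen, gives in this assay a number 10 percentage points lower from compound 3 to compound 4 (within the scatter). Set beside the first core, the two steps do not differ by more than such steps scatter, so the result fits a change that carries over from one core to the other with a similar size and the same sign of effect: the same change on two cores in this assay, a number 17 percentage points lower (beyond the scatter) from compound 2 to compound 1 and a number 10 percentage points lower (within the scatter) from compound 3 to compound 4, 7 percentage points apart, within the scatter of two such steps.

This does not show that the change has a fixed size or that it lowers the number on the second core taken alone, since that step is printed as within the scatter, and two cores are too few to support a rule for the wider series. Nothing here explains the agreement, and it says nothing about how either compound acts on nucleic acid.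

The compounds shown leave open how other groups at this place would read on these two cores, for example a cyclohexyl ring in place of the benzyl, which would separate aromatic from saturated rings, or a carboxylic acid on the chain. Also open, from the compounds shown here alone, is whether the same change holds on a third core.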